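A few compounds are considered here, and "the series" means these few. Any claim that something is new, unique, unknown or untested is made for them only; others in the source may bear on it.

Among the three compounds with numbers in hand, compound 2 `CCCC(C(C)C)n1ccc2cc(/C(C)=C/C(=O)Nc3ccccc3OCCCC(=O)O)ccc21` stands lowest in an assay on Prostate gland for inhibition of steroid 5-alpha-reductase (Rattus norvegicus) (on this read-out higher numbers stand for weaker inhibition and lower numbers for stronger inhibition), where compound 2 gives 7.2 nM. Compound 1 `CCCCCCCn1ccc2cc(/C(C)=C/C(=O)Nc3ccccc3OCCCC(=O)O)ccc21` gives 120 nM, and compound 3 `C/C(=C\C(=O)Nc1ccccc1OCCCC(=O)O)c1ccc2c(ccn2Cc2cccc(C)c2)c1` gives 250 nM. Compound 4 `CCCC(c1ccccc1)n1ccc2cc(/C(C)=C/C(=O)Nc3ccccc3OCCCC(=O)O)ccc21` is not yet measured; it differs from compound 2 by phenyl in place of isopropyl on a saturated chain carbon bound to an aromatic nitrogen and a saturated chain carbon. Within the data shown here, two measured steps bear on this change. The step of a 17-fold lower number from compound 1 to compound 2 (1.22 log units; beyond the scatter) shows that branching at the carbon bound to the aromatic nitrogen went with a large gain, and compound 4 keeps that branching. The step of a 2.1-fold higher number from compound 1 to compound 3 (0.32 log units; beyond the scatter) shows that an aromatic ring in place of an alkyl chain at the same kind of position went with a modest loss, while a 35-fold higher number from compound 2 to compound 3 (1.54 log units; beyond the scatter) combined the loss of branching with the aromatic ring and was large. Since compound 4 retains the branch but takes on the ring, the step of a 2.8-fold higher number from compound 2 to compound 4 (0.44 log units; beyond the scatter) is expected to be a modest rise beyond the scatter, and compound 4 is estimated at 20 nM, ranging from 7 nM to 60 nM.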

Compound 4, half-maximal inhibitory concentration: 9.1 nM
Compound 4: middle estimate off by 2.2-fold (0.34 log units), on the high side; the range from low to high includes it.
By their numbers in this assay, from the lowest: compounds 2 and 4 (each within the scatter of the next); then compound 1; then compound 3.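

In this assay, a 1.3-fold higher number from compound 2 to compound 4 (0.10 log units; within the scatter) shows that phenyl and isopropyl cannot be told apart on this saturated chain carbon bound to an aromatic nitrogen and a saturated chain carbon, so a ring here need not carry a loss when the carbon is branched. The branch also holds up with the ring in place: 1-phenylbutyl gives a 13-fold lower number from compound 1 to compound 4 (1.12 log units; beyond the scatter) against heptyl and a 27-fold lower number from compound 3 to compound 4 (1.44 log units; beyond the scatter) against 3-methylbenzyl, and none of the four compounds goes against this. Nothing given here explains these results.

On these data alone, whether a ring on this carbon tolerates added groups, such as a methoxy group or a chlorine on the phenyl, stays open. So does whether a cyclohexyl ring would serve as phenyl does, or whether an ethyl or a longer chain could replace the propyl part of 1-phenylbutyl.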